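The source may hold more compounds than are shown below. What is called first, only, known or untested is meant among the compounds shown, and "the series" means these compounds.

Working notes on the series, read in a physicochemical assay for lipophilicity, read by LC-MS, using the shake flask method, in phosphate buffer, measured as octanol-water partition, with a stated time of 2 h, at pH 7.4; on this read-out lower numbers stand for lower lipophilicity and higher numbers for higher lipophilicity. Compound 2 `OC[C@H]1O[C@H](OCc2cn(-c3cccc(F)c3)nn2)[C@@H](O)[C@@H](O)[C@@H]1O` gives 0.18 and compound 1 `Nc1ccc(-n2cc(CO[C@H]3O[C@H](CO)[C@@H](O)[C@H](O)[C@@H]3O)nn2)cc1` gives 0.2, so the two lie within the scatter of each other. The next compound is compound 3 `COc1ccc(-n2cc(CO[C@H]3O[C@H](CO)[C@@H](O)[C@H](O)[C@@H]3O)nn2)cc1`, not yet measured, which carries 4-methoxyphenyl in place of 3-fluorophenyl on an aromatic nitrogen. For the measured compounds named here, the one measured step at this place, 3-fluorophenyl in place of 4-aminophenyl, is a number 0.02 log units lower from compound 1 to compound 2 (within the scatter). Going by the values given here, that single step is the only guide, and no measured compound carries 4-methoxyphenyl. A change beyond the scatter is therefore not expected in this assay, and no clear direction can be expected either. The expected step is a number 0.07 log units higher from compound 2 to compound 3 (within the scatter). The estimate for compound 3 is 0.25, with an expected range from -0.1 to 0.6.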

Compound 3, distribution coefficient: -0.05
The estimate for compound 3 lay 0.30 log units above the measured number; measured number inside the range.
By their numbers in this assay, from the lowest: compounds 3, 2 and 1 (each within the scatter of the next).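

In this assay, 4-methoxyphenyl in place of 3-fluorophenyl on the aromatic nitrogen gives a number 0.23 log units lower from compound 2 to compound 3 (within the scatter) and methoxy in place of amino gives a number 0.25 log units lower from compound 1 to compound 3 (within the scatter) on an aromatic carbon. The three groups at this place, 4-aminophenyl, 3-fluorophenyl and 4-methoxyphenyl, now all stand within the scatter of one another, so the entry of a group with one hydrogen-bond acceptor by the count gives no step beyond it here. Nothing measured in this series bears on why these numbers fall as they do.

All three compounds carry a substituted phenyl at this place on the shared core. As far as these compounds go, whether a carboxylic acid or a longer chain on that phenyl gives a step beyond the scatter stays open.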